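Stereocentre inversion at the saturated ring carbon of compound 3

The source may hold more compounds than are shown below. What is called first, only, known or untested is meant among the compounds shown, and "the series" means these compounds.

Measured compounds:
Compound 1, `CCCCCCCCCCCOc1ccccc1CCC(=O)OC[C@H]1OCCC[C@@H]1OP(=O)(O)OC[C@H](N)C(=O)O`, 0.082
Compound 2, `Cc1ccc(Oc2cccc(COc3ccccc3CCC(=O)O[C@@H]3CCCO[C@@H]3COP(=O)(O)OC[C@H](N)C(=O)O)c2)cc1`, 1.9
Compound 3, `N[C@@H](COP(=O)(O)O[C@H]1C=CCO[C@@H]1COC(=O)CCc1ccccc1OCc1cccc(Oc2ccccc2)c1)C(=O)O`, 0.25

All three were read in an assay on HEK293-A cells with probable G-protein coupled receptor 34 (Mus musculus) as the target, with a stated time of 1.5 h; on this read-out lower numbers stand for smaller maximal responses and higher numbers for larger maximal responses. Among the three numbers, compound 3 stands second highest. The nearest to it is compound 1, which lies lower by a gap beyond the scatter; the furthest is compound 2, which lies higher by a gap beyond the scatter, so the three values spread well apart and the series covers a wide span of maximal response.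

Compound 4, `N[C@@H](COP(=O)(O)O[C@@H]1C=CCO[C@@H]1COC(=O)CCc1ccccc1OCc1cccc(Oc2ccccc2)c1)C(=O)O`, has not yet been measured in this assay. Relative to compound 3 the change is the two compounds have the same atoms and bonds; at least one stereo element is drawn with a configuration in one of them and without one in the other: 1 of 4 stereo elements differ; a stereocentre at a saturated ring carbon is drawn S in compound 3 and R in compound 4.

Within the data shown here, no pair of measured compounds differs in one place only, so there is no single-point step on record to calibrate what an inverted stereocentre does here. The spread between compound 1 and compound 2 shows that the series can move far in either direction, and a stereocentre inversion on the ring that carries the phosphate and ester may well move the read-out beyond the scatter, although the sign is not fixed by anything measured. The expected step is a number 0.15 higher from compound 3 to compound 4 (beyond the scatter), stated with wide uncertainty. Compound 4 is thus estimated at 0.4 in this assay, within a range from 0.05 to 1.6.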

Compound 4, intrinsic activity: the largest response reached, as a fraction of the reference agonist's: 0.2
Compound 4: the middle estimate sits 0.20 above what was measured; measured number inside the range.
By their numbers in this assay, from the lowest: compound 1; then compounds 4 and 3 (each within the scatter of the next); then compound 2.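

In this assay, the inversion of the stereocentre at a saturated ring carbon, drawn S in one compound and R in the other, is recorded as a number 0.050 lower from compound 3 to compound 4 (within the scatter). Among these compounds, this is the first single-point step, and it gives the earlier compounds' wide spread of values a local reference: at this position, in this core, the two drawn configurations cannot be told apart on this read-out. That reading needs one qualification, as the stereochemical comparison is not fully clean, and the record at this point notes: the fact that one of compounds 3 and 4 is drawn with a defined configuration and the other without, at the place where they differ

The compounds shown leave open whether the same insensitivity to configuration would hold in the core of compound 2 or with the decyloxy-type chain of compound 1, since neither has a partner that differs from it at this stereocentre alone. They also leave open how the read-out would respond to a change of group rather than of configuration at this ring carbon, such as a phosphonate in place of the phosphate.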